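Swapping a Chloro for an Acetyl on a Shared Core

The source may hold more compounds than are shown below. What is called first, only, known or untested is meant among the compounds shown, and "the series" means these compounds.

Measured so far:
Compound 1, `c1ccc(NC2=NCCC3(CCCCC3)S2)cc1`: 63100 nM
Compound 2, `Clc1ccc(NC2=NCCC3(CCCCC3)S2)cc1`: 35500 nM

Both compounds were tested in a functional assay on a subcellular fraction from brain (Rattus norvegicus) for inhibition, read by scintillation counting, with a stated time of 5 min; on this read-out lower numbers stand for stronger inhibition and higher numbers for weaker inhibition. Compound 1 gives 63100 nM, and compound 2 gives 35500 nM. Among the compounds with values here, the one step measured, a 1.8-fold lower number from compound 1 to compound 2 (0.25 log units; within the scatter), came from putting chloro in place of hydrogen on an aromatic carbon. Compound 2 therefore shows the lowest of the two numbers, yet its gap to compound 1 is no larger than the usual scatter, so the two cannot be told apart.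

Compound 3, `CC(=O)c1ccc(NC2=NCCC3(CCCCC3)S2)cc1`, differs from compound 2 as follows: acetyl in place of chloro on an aromatic carbon. Within the data shown here, no measured step involves acetyl, and the only step at hand, a 1.8-fold lower number from compound 1 to compound 2 (0.25 log units; within the scatter), stayed within the scatter. Compound 3 is therefore expected to land close to compound 2, with the step of a 1.1-fold higher number from compound 2 to compound 3 (0.05 log units; within the scatter) estimated as small in either direction. The estimate for compound 3 is 40000 nM, in the range 10000 nM to 160000 nM.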

Compound 3, half-maximal inhibitory concentration: 81300 nM
Beside the measured number, compound 3's estimate is 2.0-fold (0.31 log units) below it; measured number inside the range.
By their numbers in this assay, from the lowest: compounds 2, 1 and 3 (each within the scatter of the next, the first and the last beyond it).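

In this assay, the position para to a large group now gives its first step beyond the scatter, a modest one, with acetyl in place of chloro (a 2.3-fold higher number from compound 2 to compound 3 (0.36 log units; beyond the scatter)). With hydrogen at this position the picture differs: acetyl in place of hydrogen stays within the scatter (a 1.3-fold higher number from compound 1 to compound 3 (0.11 log units; within the scatter)), so the only difference that can be read here lies between chloro and acetyl, and neither group can be told apart from hydrogen. Nothing at hand explains why these two groups differ.

As far as these compounds go, whether an amine or a carboxylic acid at this position would bring a larger change remains open. The compounds shown also leave open whether a group here could lower the number well beyond the scatter, rather than merely separating chloro from acetyl.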